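Swapping the sulfonyl aryl: from naphthyl to bromophenyl

The source may report more compounds than this note shows. Statements on the series, on what has been measured and on what is new or still open speak of the compounds shown alone.

In an assay on HEK293 cells for antagonist activity at P2X purinoceptor 7 (Homo sapiens), read by fluorescence, with a stated time of 2 h (a lower number here means a stronger inhibitor, a higher number a weaker inhibitor), compound 1 `O=C(c1ccc(Cl)c(C(F)(F)F)c1)N1CCC(n2cncc2-c2ccc(OS(=O)(=O)c3ccccc3)cc2)CC1` gives 702 nM, while compound 2 `O=C(c1ccc(Cl)c(C(F)(F)F)c1)N1CCC(n2cncc2-c2ccc(OS(=O)(=O)c3cccc4ccccc34)cc2)CC1` gives 3520 nM, the highest of the two numbers. For the measured compounds named here, the only measured step, a 5.0-fold higher number from compound 1 to compound 2 (0.70 log units; beyond the scatter), shows that enlarging the group on the sulfonyl sulfur weakened inhibition. Compound 3 `O=C(c1ccc(Cl)c(C(F)(F)F)c1)N1CCC(n2cncc2-c2ccc(OS(=O)(=O)c3cccc(Br)c3)cc2)CC1` carries the change (3-bromophenyl in place of naphthalen-1-yl on a sulfonyl sulfur), which largely undoes that enlargement, so a lower number is expected in this assay. For compound 3 the estimate is 900 nM, with a range of 300 nM to 2700 nM, meaning an expected step of a 3.9-fold lower number from compound 2 to compound 3 (0.59 log units; beyond the scatter).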

Compound 3, half-maximal inhibitory concentration: 896 nM
For compound 3 the middle estimate is 1.0-fold (0.00 log units) above the measured one; the measured number falls inside the stated range.
By their numbers in this assay, from the lowest: compounds 1 and 3 (each within the scatter of the next); then compound 2.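

In this assay the change to 3-bromophenyl gives a 3.9-fold lower number from compound 2 to compound 3 (0.59 log units; beyond the scatter) and so shows that a single aromatic ring carrying a bromine suits this place on the sulfonyl sulfur better than naphthalen-1-yl. Adding the bromo to the plain phenyl of compound 1 gives a 1.3-fold higher number from compound 1 to compound 3 (0.11 log units; within the scatter) and so makes no readable difference. Nothing measured here explains either result. Still open, on these data alone, is what an amine or a carboxylic acid in place of the bromo would do to the inhibition.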